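From pyrazolyl to methoxyphenyl on the shared core

The source may report more compounds than this note shows. Statements on the series, on what has been measured and on what is new or still open speak of the compounds shown alone.

Compound 1 `C=C(F)C(=O)Nc1cccc(Oc2nc(Nc3ccn(C)n3)nc3c2CSCC3)c1` gives > 50000 nM in a functional assay on A549 cells (Homo sapiens) for antiproliferative activity, read by MTT assay, with a stated time of 72 h (on this read-out lower numbers stand for stronger inhibition and higher numbers for weaker inhibition), which is a limit of the assay and not a number. This places compound 1 at the limit of > 50000 nM in this assay, at which 1 of the 2 values shown sits.

Compound 2 `C=C(C)C(=O)Nc1cccc(Oc2nc(Nc3ccn(C)n3)nc3c2CSCC3)c1` carries methyl in place of fluoro on the double-bonded chain carbon bound to the carbonyl carbon, and in this assay compound 2 gives 46900 nM. Going by the values given here, the only measured step is an at least 1.0-fold lower number from compound 1 to compound 2 (0.02 log units; that floor lies within the scatter).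

Compound 3 `C=C(F)C(=O)Nc1cccc(Oc2nc(Nc3cccc(OC)c3)nc3c2CSCC3)c1` keeps the fluoro chain of compound 1 but differs elsewhere, with 3-methoxyphenyl in place of 1-methyl-1H-pyrazol-3-yl on a nitrogen on an aromatic ring. The measured step lies at the chain, not on this nitrogen, so it bears only indirectly on the exchange and gives no size for it. Among the compounds with values here, with compound 2 at 46900 nM as the sole number available, a moderate move towards a lower number is expected. Another limit remains possible for compound 3. The expected step is an at least 2.2-fold lower number from compound 1 to compound 3 (0.35 log units; beyond the scatter). Compound 3 is estimated at 22000 nM, with an expected range from 6000 nM to 50000 nM.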

Compound 3, half-maximal inhibitory concentration: 29600 nM
Compound 3: middle estimate off by 1.3-fold (0.13 log units), on the low side; the range from low to high includes it.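

The exchange of 1-methyl-1H-pyrazol-3-yl for 3-methoxyphenyl on a nitrogen on an aromatic ring, with the fluoro chain kept, gives an at least 1.6-fold lower number from compound 1 to compound 3 (0.22 log units; that floor lies within the scatter) in this assay. Going by these compounds alone, this is the first view of this nitrogen position, since the earlier pair differed only at the chain, and with the fluoro chain in place compound 3 gives a measured number of 29600 nM, so this pairing of chain and group falls inside the range of the assay. Compound 1, the other end of the step, stands at a limit of the assay and not at a number, so the printed floor is all that can be said of the size of the exchange: the limit of > 50000 nM in this assay, at which 1 of the 3 values shown sits.

The compounds shown leave open how large the step really is, and whether 3-methoxyphenyl on this nitrogen would read the same alongside the methyl chain of compound 2. They also leave open how a plain phenyl without the methoxy group, or a 3-aminophenyl, would read at this same nitrogen on the shared core.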